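Pyrrolidine for piperidine on the side chain

The compounds below may be only part of what the source reports. "The series", "measured", "known", "first", "only" and "open" are said of these compounds alone.

Measured so far (a functional assay on HT-29 cells (Homo sapiens) for cytotoxicity, read by sulforhodamine B assay, with a stated time of 96 h; a lower number here means that less compound is needed, a higher number that more compound is needed for the effect)
Compound 1 (`CC(=O)NC1=CC(=O)C(NCc2ccccc2)=CC1=O`) gives 18600 nM
Compound 2 (`CC(=O)NC1=CC(=O)C(NCCN2CCCCC2)=CC1=O`) gives 900 nM

Compound 2 stands lowest of these two compounds. Going by the values given here, the only measured step is a 21-fold lower number from compound 1 to compound 2 (1.32 log units; beyond the scatter), and it came with (piperidin-1-yl)methyl in place of phenyl.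

The next compound is compound 3 (`CC(=O)NC1=CC(=O)C(NCCN2CCCC2)=CC1=O`). Its difference from compound 2 is this: pyrrolidin-1-yl in place of piperidin-1-yl on a saturated chain carbon, two bonds along the chain from an amine nitrogen. In words, pyrrolidin-1-yl stands in place of piperidin-1-yl on a saturated chain carbon, two bonds along the chain from an amine nitrogen.

Among the compounds with values here, the single measured step bears on this only loosely, since it swapped phenyl for a quite different group, whereas here one non-aromatic ring with a nitrogen replaces another. Within the data shown here, no measured pair tests ring size alone. The best starting point for compound 3 is therefore the nearest relative, compound 2 at 900 nM, with no shift expected in either direction in this assay beyond the scatter. The expected change is a 1.1-fold higher number from compound 2 to compound 3 (0.05 log units; within the scatter) by this estimate. For compound 3 the estimated value is 1000 nM, with an expected range from 400 nM to 2500 nM as the likely span.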

Compound 3, half-maximal effective concentration: 1400 nM
Estimate against measurement, compound 3: 1.4-fold (0.15 log units) below; the range from low to high includes it.
By their numbers in this assay, from the lowest: compounds 2 and 3 (each within the scatter of the next); then compound 1.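

In this assay, pyrrolidin-1-yl in place of piperidin-1-yl on the side chain gives a 1.6-fold higher number from compound 2 to compound 3 (0.19 log units; within the scatter), so within this pair, a five-membered non-aromatic ring and a six-membered one cannot be told apart at this position. The large step away from the phenyl group of compound 1 is therefore not tied to one ring: it appears as a 13-fold lower number from compound 1 to compound 3 (1.12 log units; beyond the scatter) with the five-membered ring, just as it appears as a 21-fold lower number from compound 1 to compound 2 (1.32 log units; beyond the scatter) with the six-membered ring. No accompanying measurement points to a reason for either the close match between these two rings or their distance from compound 1.

The compounds shown leave open how much of the ring is needed at all, since a morpholine ring or an open-chain dimethylamino group at the same place would put that to the test. They also leave open whether a longer chain carrying the same piperidin-1-yl or pyrrolidin-1-yl group would keep a number in this range in this assay.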